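Removing the Methoxy Group: Expecting a Level Read-out

The source may report more compounds than this note shows. Statements on the series, on what has been measured and on what is new or still open speak of the compounds shown alone.

Of the compounds shown here, two sharing one core have so far been tested in an assay on CHO cells for displacement of a labelled ligand from adenosine receptor A1 (Homo sapiens), read by scintillation counting, tested at 10 uM; a lower number here means less inhibition, a higher number more inhibition at the concentration tested (going by the name of the read-out). Compound 1 `CC(C)(C)Cc1c(-c2ccc(F)cc2)sc(N)c1C(=O)c1ccc(Cl)cc1` carries a 4-fluorophenyl group, while compound 2 `COc1cccc(-c2sc(N)c(C(=O)c3ccc(Cl)cc3)c2CC(C)(C)C)c1` carries a 3-methoxyphenyl group in its place on an aromatic carbon. In this assay compound 1 gives 1%, and compound 2 gives 1%, so the step of no change at the digits printed from compound 1 to compound 2 (within the scatter) shows no change within the scatter. Compound 2 therefore stands level with compound 1, both at the bottom of the scale, displacing essentially none of the labelled ligand at the concentration tested.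

Compound 3 `CC(C)(C)Cc1c(-c2ccccc2)sc(N)c1C(=O)c1ccc(Cl)cc1` differs from compound 2 in one place: hydrogen in place of methoxy on an aromatic carbon. Within the data shown here, the only measured step bearing on this part of the molecule is no change at the digits printed from compound 1 to compound 2 (within the scatter), where a different substituent on the same phenyl left the read-out unchanged. With both measured compounds level at the same number and the phenyl substituent having made no difference so far, the expected step of a number 1 percentage points higher from compound 2 to compound 3 (within the scatter) is none beyond the scatter. Compound 3 is estimated at 2%, with a range from -8% to 12%.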

Compound 3, a percentage reported as inhibition, at one concentration (the size of the read-out at that concentration, not a potency): 1%
Beside the measured number, compound 3's estimate is 1 percentage points above it, and the stated range covers the measured number.
By their numbers in this assay, from the lowest: compounds 1, 2 and 3 (each within the scatter of the next).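

In this assay the methoxy group comes off the phenyl ring with no change at the digits printed from compound 2 to compound 3 (within the scatter) as the outcome, and the fluoro group comes off with no change at the digits printed from compound 1 to compound 3 (within the scatter) as the outcome, so the plain phenyl now gives a reference point that the earlier pair lacked. Compound 1 and compound 2 could only be set against each other, one substituent against another, whereas these steps set each substituent against bare hydrogen and neither stands apart from it. All three compounds lie at the bottom of the scale at the single concentration tested, which leaves no room to rank these groups, and no measurement shown offers an explanation for this flat result.

On these data alone, what stays open is whether a group of another kind on this phenyl ring, such as an amine, a carboxylic acid or a longer chain, would lift the read-out from the bottom of the scale. Also open is whether a change elsewhere on the shared core would do so, as every compound shown differs only on this ring.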